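The source may report more compounds than this note shows. Statements on the series, on what has been measured and on what is new or still open speak of the compounds shown alone.

Measured compounds:
- compound 1, `O=C(CCCCC[C@H](NC(=O)c1ccc(Br)cc1)C(=O)Nc1ccc(-c2ccccc2)cc1)NO`: 102 nM
- compound 2, `CN(C)c1ccc(C(=O)N[C@@H](CCCCCC(=O)NO)C(=O)Nc2cccc3cccnc23)cc1`: 32 nM

Of the compounds shown here, two have been tested in a functional assay on SK-MEL-5 cells (Homo sapiens) for antiproliferative activity; on this read-out higher numbers stand for weaker inhibition and lower numbers for stronger inhibition. Compound 1 gives 102 nM in this assay, and compound 2 gives 32 nM. Of these two numbers, that of compound 2 is the lower, and its gap to compound 1 lies beyond the scatter, so compound 2 stands as the stronger inhibitor of the pair.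

Compound 3, `O=C(/C=C/c1ccccc1)N[C@@H](CCCCCC(=O)NO)C(=O)Nc1cccc2cccnc12`, has not yet been measured in this assay. It differs from compound 2 in one place: 2-phenylethenyl in place of 4-(dimethylamino)phenyl on a carbonyl carbon. The rest of the molecule, including the hydroxamic acid chain and the aromatic amide on the other side, is unchanged.

Going by the values given here, no measured pair in this set shows what such a swap of the cap group does, so the expectation rests on compound 2 alone. With no other guide, the change is expected to be small, probably no more than a modest weakening, and possibly none beyond the scatter, so that the step from compound 2 to compound 3 is estimated at a 1.4-fold higher number from compound 2 to compound 3 (0.15 log units; within the scatter). Compound 3 is therefore expected to give about 45 nM in this assay, within a range of 15 nM to 150 nM.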

Compound 3, half-maximal inhibitory concentration: 29 nM
For compound 3 the middle estimate is 1.6-fold (0.19 log units) above the measured one; the range from low to high includes it.
By their numbers in this assay, from the lowest: compounds 3 and 2 (each within the scatter of the next); then compound 1.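

In this assay, going by these compounds alone, putting 2-phenylethenyl in place of 4-(dimethylamino)phenyl on a carbonyl carbon gives a 1.1-fold lower number from compound 2 to compound 3 (0.04 log units; within the scatter), the first single-place step in this set. At this place, the dimethylamino nitrogen can therefore be given up and a double bond outside the aromatic rings brought in, with the six-membered aromatic ring of carbon kept, without moving the number beyond the scatter. Nothing available accounts for why the two groups read alike.

The compounds shown leave open whether an aromatic ring is needed on this carbonyl carbon at all, as both groups carry one, and a plain methyl, a cyclohexyl ring or a saturated two-carbon chain ending in phenyl could answer that. They also leave open how a carboxylic acid or a primary amine on the ring would read, and whether the same swap would give a similar step on the core of compound 1.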